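A nitrophenyl ester arm in place of a dihydroxyphenyl one

The source may hold more compounds than are shown below. What is called first, only, known or untested is meant among the compounds shown, and "the series" means these compounds.

Measured so far:
compound 1 `C/C=C1/[C@H](O[C@@H]2O[C@H](CO)[C@@H](O)[C@H](O)[C@H]2O)OC=C(C(=O)OC)[C@H]1CC(=O)OCCc1ccc(O)c(O)c1`: 160000 nM
compound 2 `C/C=C1/[C@H](O[C@@H]2O[C@H](COC(C)=O)[C@@H](OC(C)=O)[C@H](OC(C)=O)[C@H]2OC(C)=O)OC=C(C(=O)O)[C@H]1CC(=O)OC`: > 20000 nM
compound 3 `C/C=C1/[C@H](O[C@@H]2O[C@H](CO)[C@@H](O)[C@H](O)[C@H]2O)OC=C(C(=O)OC)[C@H]1CC(=O)OCCCCCCCCCCCCCCC`: 1600 nM

All three share one core and differ only in the ester arm. In a functional assay on SK-BR-3 cells (Homo sapiens) for antiproliferative activity, read by MTT assay, with a stated time of 72 h (on this read-out higher numbers stand for weaker inhibition and lower numbers for stronger inhibition), compound 1 gives 160000 nM, the highest of the two numbers reported, while compound 3 lies far lower at 1600 nM, well beyond the scatter. For compound 2 only a limit is reported, > 20000 nM; that is a limit of the assay, not a number, and it is the limit of > 20000 nM in this assay, at which 1 of the 3 values shown sits.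

Compound 4 `C/C=C1/[C@H](O[C@@H]2O[C@H](CO)[C@@H](O)[C@H](O)[C@H]2O)OC=C(C(=O)OC)[C@H]1CC(=O)OCCc1ccc([N+](=O)[O-])cc1` is compound 1 changed in one place: 4-nitrophenyl in place of 3,4-dihydroxyphenyl on a saturated chain carbon, two bonds along the chain from an oxygen next to a carbonyl group. Within the data shown here, no measured pair shows this particular change, so its effect can only be judged loosely from compound 3 against compound 1, where a chain without hydroxyl groups gave the stronger inhibition. A moderate move toward stronger inhibition is therefore expected, a 4.0-fold lower number from compound 1 to compound 4 (0.60 log units; beyond the scatter). Compound 4 is estimated at 40000 nM, within 8000 nM to 200000 nM.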

Compound 4, half-maximal inhibitory concentration: > 20000 nM
Compound 4 ended at the assay's limit; the forecaster's own chance of this, stated with the estimate: 20%; the middle value does not contradict the limit.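

In this assay, among these compounds, compound 4 gives > 20000 nM, which is a limit and not a number, so no step from compound 1 to it can be read. The compounds shown leave open how far, and in which direction, 4-nitrophenyl in place of 3,4-dihydroxyphenyl shifts inhibition.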